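Dropping one bromine from a dibromophenyl triazine

This account rests on a few compounds, and the source may have more. Where it says the series, first, only, none or still open, it means among the compounds named here.

Measured compounds:
compound 1, `Nc1nc(N)nc(-c2cc(Br)ccc2Br)n1`, 2.09
compound 2, `CSc1cccc(-c2nc(N)nc(N)n2)c1`, 2.16
compound 3, `C=CCn1c(=O)c(N(C)C)c(C)n(-c2ccccc2)c1=O`, 1.98

Of the compounds shown here, three have been measured in a physicochemical assay for lipophilicity; a lower number here means a more polar compound, a higher number a more lipophilic compound. Compound 1 gives 2.09, compound 2 gives 2.16 and compound 3 gives 1.98. The gaps between compound 1 and each of the others lie within the scatter of repeated measurements, so on these numbers the three cannot be told apart.

Compound 4, `Nc1nc(N)nc(-c2ccccc2Br)n1`, has not been measured yet. It differs from compound 1 in one place: hydrogen in place of bromo on an aromatic carbon. Within the data shown here, no pair of measured compounds differing in exactly one place is available, so the size of this step cannot be read from the data here. Taking a bromo group off an aromatic carbon and leaving hydrogen usually makes a compound noticeably more polar, well beyond the scatter. Compound 4 is therefore expected to sit lower than compound 1 in this assay, an estimated step of a number 0.84 log units lower from compound 1 to compound 4 (beyond the scatter). Compound 4 is expected to give about 1.25, with a likely range from 0.85 to 1.65.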

Compound 4, partition coefficient: 1.26
Compound 4: middle estimate off by 0.01 log units, on the low side, within the range that was stated.
By their numbers in this assay, from the lowest: compound 4; then compounds 3, 1 and 2 (each within the scatter of the next).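

In this assay, among these compounds, this is the first step in the set that changes only one place, so the contribution of a single bromo group can be read directly rather than inferred from compounds that differ in several places. Hydrogen in place of the bromo group meta to a group of 8 heavy atoms, with the other bromo group still para to this position, gives a number 0.83 log units lower from compound 1 to compound 4 (beyond the scatter), so the loss of one heavy atom here is enough to move the value beyond the scatter. Nothing available explains the size of this step.

From the compounds shown here alone, how a chloro group, a methoxy group or an amine at this same carbon would compare with bromo and hydrogen remains open. Also open, going by these compounds, is whether taking off the remaining bromo group would give a step of similar size.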